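The source may hold more compounds than are shown below. What is called first, only, known or untested is meant among the compounds shown, and "the series" means these compounds.

Of the compounds shown here, three sharing one core have been measured in a functional assay on MGC-803 cells (Homo sapiens) for inhibition, read by sulforhodamine B assay, with a stated time of 72 h, tested at 10 uM; on this read-out higher numbers stand for more inhibition at the one concentration tested (going by the name of the read-out) and lower numbers for less inhibition. Compound 1, `Cc1cc(Nc2ccc(C(=O)/C=C/c3cccc(Br)n3)cc2)n2nc(SCc3ccccc3)nc2n1`, gives 90.2%. Compound 2, `Cc1cc(Nc2ccc(C(=O)/C=C/c3cccc(Br)n3)cc2)n2nc(SCc3ccccc3[N+](=O)[O-])nc2n1`, gives 92.3%. Compound 3, `Cc1cc(Nc2ccc(C(=O)/C=C/c3cccc(Br)n3)cc2)n2nc(SCc3nc4ccccc4[nH]3)nc2n1`, gives 94.4%. Compound 3 holds the highest of the three numbers, yet every gap is small: the step of a number 4.2 percentage points higher from compound 1 to compound 3 (within the scatter) and the step of a number 2.1 percentage points higher from compound 2 to compound 3 (within the scatter) are both within the scatter, so no order among the three can be read from them.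

Compound 4, `Cc1cc(Nc2ccc(C(=O)/C=C/c3ccc(Br)cn3)cc2)n2nc(SCc3nc4ccccc4[nH]3)nc2n1`, has not yet been measured. It differs from compound 3 in one place: 5-bromopyridin-2-yl in place of 6-bromopyridin-2-yl on a double-bonded chain carbon bound to a double-bonded chain carbon. The bromine thus moves to a different position on the pyridine ring at the far end of the chain, while the rest of the molecule is unchanged.

Among the measured compounds shown here, none of the measured steps touches this part of the molecule. The steps of a number 2.1 percentage points higher from compound 1 to compound 2 (within the scatter), a number 4.2 percentage points higher from compound 1 to compound 3 (within the scatter) and a number 2.1 percentage points higher from compound 2 to compound 3 (within the scatter) all concern the group carried on the sulfur, and all stayed within the scatter. For the measured compounds named here, the data therefore give no measured step that bears on moving the bromine, only the observation that the three changes made so far have left this assay almost unmoved.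

On that basis the step of a number 4.4 percentage points lower from compound 3 to compound 4 (within the scatter) is expected to stay within the scatter. Compound 4 is estimated at 90%, with a range from 78% to 97%.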

Compound 4, a percentage reported as inhibition, at one concentration (the size of the read-out at that concentration, not a potency): 96.8%
For compound 4 the middle estimate is 6.8 percentage points below the measured one; measured number inside the range.
By their numbers in this assay, from the lowest: compounds 1, 2, 3 and 4 (each within the scatter of the next).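

Moving the bromine is the first measured change at this end of the molecule. In this assay, 5-bromopyridin-2-yl in place of 6-bromopyridin-2-yl gives a number 2.4 percentage points higher from compound 3 to compound 4 (within the scatter), so the read-out is as insensitive to this rearrangement of the same atoms on the double-bonded chain carbon as it was to the earlier changes to the group on the sulfur. No measurement shown here offers an explanation for this result.

Going by these compounds, this single swap says nothing about whether the pyridine ring needs its bromine at all, so it remains open whether an amine or a carboxylic acid in place of the bromine would leave the read-out just as unmoved. On these data alone, a reading at one concentration is also not a potency, so it remains open whether compound 3 and compound 4 would differ in a full concentration series.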